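The source may hold more compounds than are shown below. What is called first, only, known or untested is meant among the compounds shown, and "the series" means these compounds.

Compound 1, `CC(C)c1ccc(/C=C/C(=O)Nc2ccc3c(c2)OCCO3)cc1`, in a functional assay on CHO cells for inhibition of transient receptor potential cation channel subfamily V member 1 (Homo sapiens); on this read-out lower numbers stand for stronger inhibition and higher numbers for weaker inhibition: 82 nM
Compound 2, `CCCCc1ccc(/C=C/C(=O)Nc2ccc3c(c2)OCCO3)cc1`, in this assay: 2700 nM
Compound 3, `O=C(/C=C/c1ccc(-c2ccccc2)cc1)Nc1ccc2c(c1)OCCO2`, in this assay: > 4000 nM

The three share one core and differ only in the group on the far aromatic ring. Compound 1 gives the lowest number. Among the measured compounds shown here, for compound 3 the result is only a limit of the assay, > 4000 nM, so its true value is unknown beyond that; it is the one value sitting at the limit of > 4000 nM in this assay, at which 1 of the 3 values shown sits. Compound 3 therefore stands at the weak end of what has been measured.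

The measured steps show that leaving isopropyl costs strongly: a 33-fold higher number from compound 1 to compound 2 (1.52 log units; beyond the scatter) and an at least 48-fold higher number from compound 1 to compound 3 (1.68 log units; beyond the scatter). Between the two larger groups the step is small: an at least 1.4-fold higher number from compound 2 to compound 3 (0.17 log units; that floor lies within the scatter).

Compound 4, `O=C(/C=C/c1ccc(Cl)cc1)Nc1ccc2c(c1)OCCO2`, differs from compound 3 by chloro in place of phenyl on an aromatic carbon. For the measured compounds named here, no measured step covers chloro itself, so the expectation rests on the counted size alone: the entering group is far smaller than phenyl and closer in heavy-atom count to the isopropyl of compound 1 than to butyl or phenyl. A step of an at least 20-fold lower number from compound 3 to compound 4 (1.30 log units; beyond the scatter) is therefore expected, toward stronger inhibition. Compound 4 is estimated at 200 nM, within a range from 40 nM to 2000 nM.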

Compound 4, half-maximal inhibitory concentration: 320 nM
For compound 4 the middle estimate is 1.6-fold (0.20 log units) below the measured one; low and high end bracket the measured number.
By their numbers in this assay, from the lowest: compound 1; then compound 4; then compound 2. At a limit, above all of these: compound 3.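

In this assay, a single chlorine atom on this aromatic carbon, para to a large group, gives much of the ground back that the larger groups lost, with an 8.4-fold lower number from compound 2 to compound 4 (0.93 log units; beyond the scatter) and an at least 12-fold lower number from compound 3 to compound 4 (1.09 log units; beyond the scatter). Chloro still does not match isopropyl, with a 3.9-fold higher number from compound 1 to compound 4 (0.59 log units; beyond the scatter), so among these four compounds the smallest group does not give the lowest number, and the order does not simply follow group size. Compound 3 has only a limit rather than a number, so its step gives a floor and not a true size: the limit of > 4000 nM in this assay, at which 1 of the 4 values shown sits.

The compounds shown cannot tell whether chloro owes its result to its size or to something particular to chlorine. A methyl, a bromo, a tert-butyl or a trifluoromethyl group at the same place could help to separate these two readings.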